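This account rests on a few compounds, and the source may have more. Where it says the series, first, only, none or still open, it means among the compounds named here.

Measured in a functional assay on HeLa cells (Homo sapiens) for antiproliferative activity, read by MTT assay, with a stated time of 48 h; on this read-out lower numbers stand for stronger inhibition and higher numbers for weaker inhibition:
- compound 1 `O=C(OCc1ccccc1)c1ccc2[nH]c(-c3cn(-c4ccccc4)nc3-c3ccccc3)nc2c1`: 21300 nM
- compound 2 `Cc1ccc2[nH]c(-c3cn(-c4ccccc4)nc3-c3ccc(F)cc3)nc2c1`: 3630 nM

Compound 2, at 3630 nM, holds the lower of the two numbers in this assay, and the gap up to compound 1 lies beyond the scatter. Compound 3 `O=C(OCc1ccccc1)c1ccc2[nH]c(-c3cn(-c4ccccc4)nc3-c3ccc(F)cc3)nc2c1` has not yet been measured. It replaces the methyl of compound 2 with benzyloxycarbonyl on an aromatic carbon: benzyloxycarbonyl in place of methyl on an aromatic carbon. Among the compounds with values here, no step between measured compounds isolates this change, so the evidence is indirect. Compound 1 also carries benzyloxycarbonyl and gives 21300 nM, so a rise toward weaker inhibition is expected in this assay, probably beyond the scatter. The expected change is a 2.5-fold higher number from compound 2 to compound 3 (0.39 log units; beyond the scatter). For compound 3 the estimated value is 9000 nM, with an expected range from 2500 nM to 30000 nM.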

Compound 3, half-maximal inhibitory concentration: 23600 nM
The estimate for compound 3 lay 2.6-fold (0.42 log units) below the measured number, and the stated range covers the measured number.
By their numbers in this assay, from the lowest: compound 2; then compounds 1 and 3 (each within the scatter of the next).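

In this assay, the exchange at this aromatic carbon now has a step of its own: benzyloxycarbonyl in place of methyl gives a 6.5-fold higher number from compound 2 to compound 3 (0.81 log units; beyond the scatter), so the larger ester group goes with weaker inhibition when the rest of the molecule stays the same. With benzyloxycarbonyl held in place, fluoro in place of hydrogen on an aromatic carbon gives a 1.1-fold higher number from compound 1 to compound 3 (0.04 log units; within the scatter), so that exchange does not separate these two compounds. Nothing measured here accounts for the loss seen with benzyloxycarbonyl.

The compounds shown leave open whether a carboxylic acid or a methyl ester on this carbon would stay close to compound 2 or to compound 3. They also leave open whether fluoro in place of hydrogen would make a difference when methyl occupies this carbon.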